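Fluorophenoxy in Place of Dichlorophenoxy on a Diamine Core

The source may report more compounds than this note shows. Statements on the series, on what has been measured and on what is new or still open speak of the compounds shown alone.

compound 1, `Nc1cc(N)c2nc(-c3ccccc3)c(Oc3ccc(Cl)c(Cl)c3)nc2c1`: 41700 nM
compound 2, `CCOC(=O)[C@H](CCC(=O)O)NC(=O)c1ccc(CNc2nc3cc(N)cc(N)c3nc2-c2ccccc2)cc1`: < 100000 nM
compound 3, `COc1cc(CNc2nc3cc(N)cc(N)c3nc2-c2ccccc2)cc(OC)c1OC`: 27500 nM

In a functional assay on EKVX cells (Homo sapiens) for inhibition, read by sulforhodamine B assay, with a stated time of 48 h (on this read-out higher numbers stand for lower toxicity in this test and lower numbers for higher toxicity in this test), compound 1 gives 41700 nM. Compound 3, which carries the same core with a different group on the amine, gives 27500 nM in this assay, and the two numbers lie within the usual scatter of each other, so neither compound can be set apart from the other. Compound 2 is reported only as a limit in this assay, (the limit of < 100000 nM in this assay, at which 1 of the 3 values shown sits), and contributes no number to compare.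

Compound 4, `Nc1cc(N)c2nc(-c3ccccc3)c(Oc3ccc(F)cc3)nc2c1`, differs from compound 1 by 4-fluorophenyl in place of 3,4-dichlorophenyl on an oxygen on an aromatic ring. Within the data shown here, no measured pair in this set shares that change, so nothing here sizes it. The author expects the step from compound 1 to compound 4 in this assay to stay within the scatter, with a 1.1-fold higher number from compound 1 to compound 4 (0.03 log units; within the scatter) as the estimated shift. Compound 4 is therefore estimated at 45000 nM in this assay, within a range from 15000 nM to 120000 nM.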

Compound 4, concentration lethal to 50% of the cells: 77600 nM
Compound 4: middle estimate off by 1.7-fold (0.24 log units), on the low side; low and high end bracket the measured number.
By their numbers in this assay, from the lowest: compounds 3, 1 and 4 (each within the scatter of the next, the first and the last beyond it).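

Among these compounds, replacing 3,4-dichlorophenyl with 4-fluorophenyl on an oxygen on an aromatic ring gives a 1.9-fold higher number from compound 1 to compound 4 (0.27 log units; within the scatter) in this assay as the first measured step at this position. The position therefore accepts this exchange of ring substituents without a step beyond the scatter on this read-out, although this single pair cannot show how far that holds for other groups. Nothing in the information available bears on why the step has this size.

The compounds shown leave open whether an unsubstituted phenyl, a single chlorine or a methoxy group on the ring would also stay within the scatter of compound 1. They also leave open whether an amine or a carboxylic acid on that ring would do the same.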